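Replacing 4-methoxyphenyl with 3-(trifluoromethyl)phenyl on a carbonyl carbon

The source may report more compounds than this note shows. Statements on the series, on what has been measured and on what is new or still open speak of the compounds shown alone.

Values so far in a functional assay on a cell-free system (Platelet, plasma, Homo sapiens) for inhibition; a higher number here means a weaker inhibitor, a lower number a stronger inhibitor
Compound 1 `Cc1ccc(N(CCN2CCC(OCC(=O)O)CC2)C(=O)c2ccc(F)cc2)cc1` gives 970 nM
Compound 2 `COc1ccc(C(=O)N(CCN2CCC(OCC(=O)O)CC2)c2ccc(C)cc2)cc1` gives 1200 nM
Compound 3 `COc1cccc(C(=O)N(CCN2CCC(OCC(=O)O)CC2)c2ccc(C)cc2)c1` gives 32 nM

Compound 2 stands at the high-number end of this small set, level with compound 1. The gap there is a 1.2-fold higher number from compound 1 to compound 2 (0.09 log units; within the scatter) and so offers no real separation. Compound 3 lies far away, with a 38-fold lower number from compound 2 to compound 3 (1.57 log units; beyond the scatter) as the measured step.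

Compound 4 `Cc1ccc(N(CCN2CCC(OCC(=O)O)CC2)C(=O)c2cccc(C(F)(F)F)c2)cc1` has not yet been measured. It carries 3-(trifluoromethyl)phenyl in place of 4-methoxyphenyl on a carbonyl carbon and keeps the rest of compound 2 unchanged.

Among the compounds with values here, two measured steps bear on this change, both at the same carbonyl carbon. One is a 38-fold lower number from compound 2 to compound 3 (1.57 log units; beyond the scatter) and the other is a 30-fold lower number from compound 1 to compound 3 (1.48 log units; beyond the scatter) for the same entering group. Both favour 3-methoxyphenyl over the groups it replaced. In contrast, the swap between the fluoro and methoxy compounds made no difference beyond the scatter. Within the data shown here, no measured compound carries trifluoromethyl, so only part of the gain seen with compound 3 can be assumed to carry over.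

A large drop is therefore expected, estimated as a 17-fold lower number from compound 2 to compound 4 (1.23 log units; beyond the scatter) in this assay for this change. For compound 4 the estimated value is 70 nM within an expected range from 15 nM to 350 nM in the same read-out.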

Compound 4, half-maximal inhibitory concentration: 20000 nM
Beside the measured number, compound 4's estimate is 290-fold (2.46 log units) below it; measured number above the stated range.
By their numbers in this assay, from the lowest: compound 3; then compounds 1 and 2 (each within the scatter of the next); then compound 4.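

In this assay, a 630-fold higher number from compound 3 to compound 4 (2.80 log units; beyond the scatter) is the largest step in the set, and it shows that the gain seen with 3-methoxyphenyl on this carbonyl carbon does not simply pass to another group on the same aromatic carbon, since trifluoromethyl in place of methoxy reverses that gain completely. The change also loses ground against both earlier groups, with a 17-fold higher number from compound 2 to compound 4 (1.22 log units; beyond the scatter) for 3-(trifluoromethyl)phenyl in place of 4-methoxyphenyl and a 21-fold higher number from compound 1 to compound 4 (1.31 log units; beyond the scatter) for the same group in place of 4-fluorophenyl, so this position, which earlier gave only a gain or no change beyond the scatter, can also move strongly the other way. Nothing given here accounts for so wide a split between methoxy and trifluoromethyl on this ring.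

The compounds shown leave open whether 3-ethoxyphenyl or 3-hydroxyphenyl on this carbonyl carbon would stay near compound 3 or fall toward compound 4. They also leave open how 4-(trifluoromethyl)phenyl would read there, which would show whether the loss follows the trifluoromethyl group wherever it stands on the ring.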